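The source may report more compounds than this note shows. Statements on the series, on what has been measured and on what is new or still open speak of the compounds shown alone.

In a functional assay on the whole organism (liver, strain NMRI) for inhibition, with Mus musculus as the target, with a stated time of 3 h, at a dose of 3 mg/kg by the oral route (a lower number here means less inhibition, a higher number more inhibition at the dose given (going by the name of the read-out)), three compounds have been measured. Compound 1 `O=[N+]([O-])c1cc(-c2nc(-c3ccccc3)no2)cc(O)c1O` gives 20.6%, compound 2 `O=[N+]([O-])c1cc(-c2nc(-c3ccc(Cl)c(Cl)c3)no2)cc(O)c1O` gives 8.8%, and compound 3 `O=[N+]([O-])c1cc(-c2nc(N3CCN(c4ccccn4)CC3)no2)cc(O)c1O` gives 32.2%. Compound 2 thus stands lowest of the three numbers: its nearest neighbour is compound 1, higher beyond the scatter, and the furthest is compound 3, higher still beyond the scatter. One measured step links two of them: a number 11.8 percentage points lower from compound 1 to compound 2 (beyond the scatter), with 3,4-dichlorophenyl in place of phenyl on an aromatic carbon.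

Compound 4 `O=[N+]([O-])c1cc(-c2nc(-c3cccs3)no2)cc(O)c1O` has not yet been measured in this assay. It differs from compound 2 in one place: thiophen-2-yl in place of 3,4-dichlorophenyl on an aromatic carbon. Among the measured compounds shown here, the only measured step that bears on this change is a number 11.8 percentage points lower from compound 1 to compound 2 (beyond the scatter), in which the 3,4-dichlorophenyl entered and the number fell by a modest amount. For the measured compounds named here, compound 4 takes the 3,4-dichlorophenyl away again and brings in thiophen-2-yl; no measured pair contains thiophen-2-yl, so the expectation rests on reversing that one step. Because compound 2 lies below compound 1 by a number 11.8 percentage points lower from compound 1 to compound 2 (beyond the scatter), compound 4 is expected to move upward by a similar modest amount. Compound 4 is therefore estimated to give 19% in this assay, within a range from 7% to 31%, an expected step of a number 10.2 percentage points higher from compound 2 to compound 4 (beyond the scatter).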

Compound 4, a percentage reported as inhibition, in the whole organism at one dose (the size of the read-out at that dose, not a potency): 29.6%
Compound 4: middle estimate off by 10.6 percentage points, on the low side, and the stated range covers the measured number.
By their numbers in this assay, from the lowest: compound 2; then compounds 1, 4 and 3 (each within the scatter of the next, the first and the last beyond it).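

Replacing the 3,4-dichlorophenyl on the aromatic carbon between two ring nitrogen atoms with thiophen-2-yl gives a number 20.8 percentage points higher from compound 2 to compound 4 (beyond the scatter), while setting thiophen-2-yl against the unsubstituted phenyl gives a number 9 percentage points higher from compound 1 to compound 4 (within the scatter), so in this assay these two groups cannot be told apart. The earlier step showed only that one aromatic group could stand below another; the new compound shows that the position accepts a five-membered aromatic ring with a sulfur atom as well as a phenyl, and that among the three carbon-linked aromatic groups shown, only the 3,4-dichlorophenyl of compound 2 stands apart beyond the scatter from both others. No measurement offered here accounts for the difference between these groups.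

The compounds shown leave open whether both chlorine atoms are needed for the lower number, as a phenyl carrying a single chlorine would show, and whether a furan-2-yl would fall with thiophen-2-yl and phenyl. They also leave open how a morpholine or a carboxylic acid at this position would read at this single dose.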